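A few compounds are considered here, and "the series" means these few. Any claim that something is new, unique, unknown or untested is made for them only; others in the source may bear on it.

Measured compounds:
- compound 1 `CC(C)c1noc(-c2cccc(CNc3ccc4[nH]nc(C(=O)O)c4c3)c2O)n1`: 47 nM
- compound 2 `CN(C)c1noc(-c2cccc(CNc3ccc4[nH]ncc4c3)c2O)n1`: 12000 nM

In an assay on isolated protein for inhibition of 2-Hydroxyacid oxidase 1 (Homo sapiens), with stated times of 30 min and 15 min (on this read-out higher numbers stand for weaker inhibition and lower numbers for stronger inhibition), compound 1 gives 47 nM and holds the lowest number of the two measured compounds. Going by the values given here, compound 2 gives 12000 nM in this assay, a far higher number, beyond the scatter; compound 2 differs from compound 1 in more than one place, so the two values show only that compound 1 is the stronger inhibitor of the pair.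

Compound 3 `CC(C)c1coc(-c2cccc(CNc3ccc4[nH]nc(C(=O)O)c4c3)c2O)n1` is not yet measured in this assay. Its change from compound 1 is 4-isopropyl-1,3-oxazol-2-yl in place of 3-isopropyl-1,2,4-oxadiazol-5-yl on an aromatic carbon. Among the compounds with values here, the exchange keeps the isopropyl chain and the ring size while altering the ring heteroatoms; no measured pair shows what such a ring swap does here. For compound 3 a small step toward a higher number is expected, with a step of a 1.9-fold higher number from compound 1 to compound 3 (0.28 log units; within the scatter) that could still fall within the scatter. Compound 3 is estimated at 90 nM in this assay, with a range from 25 nM to 400 nM.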

Compound 3, half-maximal inhibitory concentration in the 2-Hydroxyacid oxidase 1 assay: 87 nM
Beside the measured number, compound 3's estimate is 1.0-fold (0.01 log units) above it, within the range that was stated.
By their numbers in the 2-Hydroxyacid oxidase 1 assay, from the lowest: compounds 1 and 3 (each within the scatter of the next); then compound 2.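

In the 2-Hydroxyacid oxidase 1 assay the exchange of 3-isopropyl-1,2,4-oxadiazol-5-yl for 4-isopropyl-1,3-oxazol-2-yl, on an aromatic carbon ortho to a hydroxy group, gives a 1.9-fold higher number from compound 1 to compound 3 (0.27 log units; within the scatter), so this first single-place pair does not separate the two rings on inhibition. In a physicochemical assay for solubility, measured as kinetic solubility, at pH 2 (a lower number here means a less soluble compound, a higher number a more soluble compound), compound 1 gives 11000 nM and compound 3 gives 4000 nM. The same exchange therefore leaves inhibition within the scatter yet lowers solubility: the measured solubility of compound 1, 11000 nM, and of compound 3, 4000 nM, a 2.8-fold lower number (0.44 log units; beyond the scatter)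

Open, as far as these compounds go, is whether a morpholine or a longer alkyl chain in place of the isopropyl on this ring would keep inhibition and solubility together. Compound 2 differs from compound 1 in more than one place, so what the carboxylic acid contributes also stays unresolved.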